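From 4-fluorophenyl to 3-chlorophenyl: a small expected step

The source may report more compounds than this note shows. Statements on the series, on what has been measured and on what is new or still open speak of the compounds shown alone.

Compound 1 `O=C(CCc1cccc2c1B(O)OC2)Nc1cccc(Br)c1`: 1400 nM
Compound 2 `O=C(CCc1cccc2c1B(O)OC2)Nc1cccc(-c2ccc(F)cc2)c1`: 550 nM

In a functional assay on HCT-116 cells (Homo sapiens) for antiproliferative activity, read by MTT assay, with a stated time of 72 h (on this read-out lower numbers stand for stronger inhibition and higher numbers for weaker inhibition), compound 2 gives 550 nM, the lower of the two numbers, so it is the stronger inhibitor of this pair. Compound 3 `O=C(CCc1cccc2c1B(O)OC2)Nc1cccc(-c2cccc(Cl)c2)c1` keeps the shared core and the chain of compound 2 and alters only the outer aromatic ring: 3-chlorophenyl in place of 4-fluorophenyl on an aromatic carbon. In short, 3-chlorophenyl stands in place of 4-fluorophenyl on an aromatic carbon.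

Within the data shown here, only one measured step bears on this change: a 2.5-fold lower number from compound 1 to compound 2 (0.41 log units; beyond the scatter). That modest step came from putting 4-fluorophenyl in place of bromo, so it replaced a single atom with a ring. The new change instead exchanges one halogen-bearing phenyl group for another. Among the measured compounds shown here, no measured pair compares two such groups, so the data point in neither direction. No step beyond the scatter is therefore expected in this assay. The estimated step is no change at the digits printed from compound 2 to compound 3 (within the scatter). For compound 3 the expected value is 550 nM, within an estimated range of 230 nM to 1300 nM.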

Compound 3, half-maximal inhibitory concentration: 350 nM
Compound 3: middle estimate off by 1.6-fold (0.20 log units), on the high side; the range from low to high includes it.
By their numbers in this assay, from the lowest: compounds 3 and 2 (each within the scatter of the next); then compound 1.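

In this assay, replacing 4-fluorophenyl with 3-chlorophenyl gives a 1.6-fold lower number from compound 2 to compound 3 (0.20 log units; within the scatter) and so shows that two different halogen-bearing phenyl groups at this position cannot be told apart by this read-out, even though the halogen and its place on the outer ring both change. The lower number seen against the bromo compound is also not limited to 4-fluorophenyl: 3-chlorophenyl in place of bromo gives a 4.0-fold lower number from compound 1 to compound 3 (0.60 log units; beyond the scatter) and so also lies beyond the scatter, as the earlier step to the 4-fluorophenyl compound did. Nothing available explains why either phenyl group goes with a lower number than bromo.

Since the halogen and its place change together, the compounds shown cannot separate the two, and a matched pair such as 4-chlorophenyl and 3-fluorophenyl would be needed to do so. As far as these compounds go, it also remains open whether a plain phenyl ring without any halogen would match these two compounds, and how an amine or a carboxylic acid on the outer ring would fare.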